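Ether side chain variation on the N-oxide core

The compounds below may be only part of what the source reports. "The series", "measured", "known", "first", "only" and "open" are said of these compounds alone.

The series shares the core seen in compound 1 `CCCOCNc1n[n+]([O-])c2cc(OC)ccc2[n+]1[O-]`, which in a functional assay on K562 cells (Homo sapiens) for cytotoxicity, read by MTT assay, with a stated time of 72 h (a lower number here means a stronger inhibitor, a higher number a weaker inhibitor), gives 3520 nM. Within the data shown here, compound 2 `[O-][n+]1nc(NCOC2CCCCC2)[n+]([O-])c2ccccc21` in this assay gives 4880 nM, the highest of the two numbers so far; its nearest neighbour is compound 1, and the gap between the two values lies within the usual scatter, so neither is set apart from the other.

Compound 3 `CC(C)CCOCNc1n[n+]([O-])c2ccccc2[n+]1[O-]` has not yet been measured. Compared with compound 2 it carries isopentyl in place of cyclohexyl on an oxygen on a saturated carbon. Among the measured compounds shown here, no measured pair in the set isolates this change, so nothing here sets its size. The two measured values sit close together despite different ether groups, and a step from compound 2 to compound 3 of about a 1.1-fold lower number from compound 2 to compound 3 (0.04 log units; within the scatter) is expected, that is, none beyond the scatter. Compound 3 is therefore expected to give about 4500 nM in this assay, in a range of 2000 nM to 10000 nM.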

Compound 3, half-maximal inhibitory concentration: 5850 nM
Compound 3: middle estimate off by 1.3-fold (0.11 log units), on the low side, within the range that was stated.
By their numbers in this assay, from the lowest: compounds 1, 2 and 3 (each within the scatter of the next).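

In this assay, among these compounds, the change from cyclohexyl to isopentyl on an oxygen on a saturated carbon gives the first step that isolates one change (a 1.2-fold higher number from compound 2 to compound 3 (0.08 log units; within the scatter)). For this pair, then, exchanging the six-membered non-aromatic ring for an open isopentyl chain leaves the two numbers within the scatter of each other, so the ring is not needed for a value of this size. No measurement in hand bears on this result.

The compounds shown leave open whether a different kind of group on this oxygen, such as an amine, a carboxylic acid or a longer chain, would give a step beyond the scatter. They also leave open whether the same change reads alike on the core of compound 1.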